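The compounds below may be only part of what the source reports. "The series", "measured", "known", "first", "only" and "open" are said of these compounds alone.

Compound 1, `CCCCNc1nc(N)nc2ccn(CC=C(C)C)c12`; in an assay on HEK293 cells for agonist activity at Toll-like receptor 8 (Homo sapiens), read by a luciferase reporter, with a stated time of 6 h (on this read-out lower numbers stand for an effect already at smaller amounts and higher numbers for an effect only at larger amounts of compound), compound 1 reaches only the assay limit, > 25 uM.
Compound 2, `CCCCNc1nc(N)nc2ccn(Cc3nccs3)c12`; in this assay compound 2 gives 2.27 uM.

Among the two values shown, compound 2 holds the only number; the other value, that of compound 1, is a limit (the limit of > 25 uM in this assay, at which 1 of the 2 values shown sits). Among the compounds with values here, the single measured step, an at least 11-fold lower number from compound 1 to compound 2 (1.04 log units; beyond the scatter), is large and sits at the very place that changes next: there 2-methylprop-1-en-1-yl gave way to 1,3-thiazol-2-yl.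

Compound 3, `CCCCNc1nc(N)nc2ccn(Cc3ccncc3)c12`, differs from compound 2 by pyridin-4-yl in place of 1,3-thiazol-2-yl on a saturated chain carbon bound to an aromatic nitrogen. This step bears on the measured one only loosely: the measured step exchanged 2-methylprop-1-en-1-yl for an aromatic ring, whereas here one aromatic ring takes the place of another. A smaller step is therefore expected, and compound 3 is expected to stay close to compound 2, with a 1.3-fold higher number from compound 2 to compound 3 (0.12 log units; within the scatter) lying within the usual scatter. The estimate for compound 3 in this assay is 3 uM, between 1 uM and 10 uM.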

Compound 3, minimum effective concentration: > 25 uM
Compound 3: a limit, no number; the forecaster's own chance of this, stated with the estimate: 15%; at least 8.3-fold (0.92 log units) between middle value and limit.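

In this assay, the exchange of one aromatic ring for another at this position proves far from neutral: pyridin-4-yl in place of 1,3-thiazol-2-yl on a saturated chain carbon bound to an aromatic nitrogen gives an at least 11-fold higher number from compound 2 to compound 3 (1.04 log units; beyond the scatter). Compound 3 reaches only a limit, > 25 uM, so an aromatic ring at this place does not by itself secure a measurable value. The step between compound 1 and compound 3 cannot be read, and compound 2 alone holds a number: the limit of > 25 uM in this assay, at which 2 of the 3 values shown sit.

The compounds shown leave open whether the step follows the ring size or the ring's hetero atoms, which a thienyl or an oxazolyl group at the same place would help to separate. Going by these compounds, whether a plain phenyl group there would give a number also remains open.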